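The source may hold more compounds than are shown below. What is called first, only, known or untested is meant among the compounds shown, and "the series" means these compounds.

Measured in a functional assay on MOLT-4 cells (Homo sapiens) for inhibition, read by MTT assay, with a stated time of 72 h; on this read-out higher numbers stand for weaker inhibition and lower numbers for stronger inhibition:
- compound 1 `COc1cc(NC(C)CCCNC(=O)Nc2cccc(F)c2)c2ncccc2c1`: 23000 nM
- compound 2 `COc1cc(NC(C)CCCNC(=O)Nc2cccc(Cl)c2)c2ncccc2c1`: 21000 nM
- compound 3 `COc1cc(NC(C)CCCNC(=O)NNC(=O)Nc2ccc(F)cc2)c2ncccc2c1`: >= 250000 nM

The entry for compound 3 is a limit of the assay, not a number. Compound 2 has one numeric neighbour, shown by a 1.1-fold lower number from compound 1 to compound 2 (0.04 log units; within the scatter). It lies far from the limit, with an at least 11-fold higher number from compound 2 to compound 3 (1.07 log units; beyond the scatter).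

Compound 4 `COc1cc(NC(C)CCCNC(=O)Nc2ccc(F)cc2)c2ncccc2c1` carries 4-fluorophenyl in place of 3-chlorophenyl on an amide-type nitrogen. The closest evidence is the exchange of halogen between compound 1 and compound 2, a 1.1-fold lower number from compound 1 to compound 2 (0.04 log units; within the scatter). The large step to compound 3 replaces the aryl group outright, so it bears little on this change. Within the data shown here, no measured step tests the move to 4-fluorophenyl, which leaves the estimate uncertain.

In this assay, a 1.0-fold higher number from compound 2 to compound 4 (0.02 log units; within the scatter) is expected, a step within the scatter. The estimated value for compound 4 is 22000 nM, with an expected range of 10000 nM to 50000 nM.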

Compound 4, half-maximal inhibitory concentration: 24000 nM
Beside the measured number, compound 4's estimate is 1.1-fold (0.04 log units) below it, and the stated range covers the measured number.
By their numbers in this assay, from the lowest: compounds 2, 1 and 4 (each within the scatter of the next). At a limit, above all of these: compound 3.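

In this assay, 4-fluorophenyl on the amide-type nitrogen behaves like either 3-halophenyl group, with a 1.1-fold higher number from compound 2 to compound 4 (0.06 log units; within the scatter) and a 1.0-fold higher number from compound 1 to compound 4 (0.02 log units; within the scatter), so neither this halogen exchange nor the new ring position shifts the number measurably. Replacing ((4-fluorophenyl)carbamoyl)amino with 4-fluorophenyl, which keeps the same fluorinated ring, gives an at least 10-fold lower number from compound 3 to compound 4 (1.01 log units; beyond the scatter), tying the large step to the carbamoylamino link and not to the ring substitution. The entry for compound 3 is a limit of the assay: the limit of >= 250000 nM in this assay, at which 1 of the 4 values shown sits.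

From the compounds shown here alone, whether an unsubstituted phenyl, a methoxy group or an amine on that ring would also leave the number unchanged stays open. So does the effect of a longer chain.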